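The compounds below may be only part of what the source reports. "The series", "measured", "known", "first", "only" and "open" are said of these compounds alone.

Working notes on the cytotoxicity series.

Among the compounds with values here, the three measured members share one core with the silyl-protected sugar and the methylated thymine-type base, and differ only in the substituent on the amine nitrogen of the cyclic sulfonate. Compound 1 `COC(=O)NC1=CS(=O)(=O)O[C@@]12[C@@H](CO[Si](C)(C)C(C)(C)C)O[C@@H](n1cc(C)c(=O)n(C)c1=O)[C@@H]2O[Si](C)(C)C(C)(C)C` carries the methoxycarbonyl there, compound 2 `COC(=O)CC(=O)NC1=CS(=O)(=O)O[C@@]12[C@@H](CO[Si](C)(C)C(C)(C)C)O[C@@H](n1cc(C)c(=O)n(C)c1=O)[C@@H]2O[Si](C)(C)C(C)(C)C` the ((methoxycarbonyl)methyl)carbonyl, and compound 3 `COC(=O)C(=O)CNC1=CS(=O)(=O)O[C@@]12[C@@H](CO[Si](C)(C)C(C)(C)C)O[C@@H](n1cc(C)c(=O)n(C)c1=O)[C@@H]2O[Si](C)(C)C(C)(C)C` the ((methoxycarbonyl)carbonyl)methyl.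

In a functional assay on HEL cells (Homo sapiens) for cytotoxicity, read by microscopy (on this read-out higher numbers stand for lower toxicity in this test and lower numbers for higher toxicity in this test), compound 2 gives 400000 nM. Compound 1 reaches only a limit of this assay, >= 50000 nM. Compound 3 likewise reaches only a limit of this assay, > 400000 nM. The steps among them are therefore not readable in size: a step that the limit leaves unreadable from compound 1 to compound 2, a step that the two limits leave unreadable from compound 1 to compound 3, and a number no lower from compound 2 to compound 3 (the limit leaves the size open). The two limits, the limit of > 400000 nM in this assay, at which 1 of the 3 values shown sits, and (the limit of >= 50000 nM in this assay, at which 1 of the 3 values shown sits), leave compound 3 at the upper edge of what this test reports, with no sign of toxicity in the readable range.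

Compound 4 `Cc1cn([C@@H]2O[C@H](CO[Si](C)(C)C(C)(C)C)[C@@]3(OS(=O)(=O)C=C3NCCC(=O)O)[C@H]2O[Si](C)(C)C(C)(C)C)c(=O)n(C)c1=O` is the next member. It differs from compound 3 as follows: carboxymethyl in place of (methoxycarbonyl)carbonyl on a saturated chain carbon bound to an amine nitrogen.

Within the data shown here, none of the measured steps is readable in size, so the step expected here is a number no higher from compound 3 to compound 4 (the limit leaves the size open). Compound 4 is estimated at 400000 nM, within 100000 nM to 400000 nM, most probably again as a limit of this assay.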

Compound 4, minimum cytotoxic concentration: 80000 nM
Compound 4: middle estimate off by 5.0-fold (0.70 log units), on the high side, and the stated range ends above it.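

On the amine nitrogen, 2-carboxyethyl brings the first readable move toward higher toxicity in this test in this assay, with a 5.0-fold lower number from compound 2 to compound 4 (0.70 log units; beyond the scatter) and an at least 5.0-fold lower number from compound 3 to compound 4 (0.69 log units; beyond the scatter). This position is therefore not silent in this assay, and the readable change comes with the only member shown whose substituent does not end in a methoxycarbonyl, though that link rests on this single compound. The second of these steps is a bound and not a measured size, because compound 3 stands at a limit of this assay: the limit of > 400000 nM in this assay, at which 1 of the 4 values shown sits.

As far as these compounds go, the remaining steps cannot be read, and those from compound 1 stay open because its value is also a limit: the limit of >= 50000 nM in this assay, at which 1 of the 4 values shown sits A methyl ester of the 2-carboxyethyl group, or an amine or a longer chain ending in a carboxylic acid in its place, would tell whether the lower number goes with the carboxylic acid end or with the chain that carries it.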